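A Naphthyl Substituent Replaces the Formylphenyl Group

The source may report more compounds than this note shows. Statements on the series, on what has been measured and on what is new or still open speak of the compounds shown alone.

Of the compounds shown here, three built on one shared core have been measured in a functional assay on OVCAR-4 cells (Homo sapiens) for inhibition, read by sulforhodamine B assay, with a stated time of 48 h, tested at 10 uM; on this read-out higher numbers stand for more inhibition at the one concentration tested (going by the name of the read-out) and lower numbers for less inhibition. Compound 1 `Brc1cn2ccnc2c(-c2ccc3ncn(C4CCCCC4)c3c2)n1` gives 9.15%. Compound 2 `c1ccc(-c2cn3ccnc3c(-c3ccc4ncn(C5CCCCC5)c4c3)n2)cc1` gives 34.5%, and compound 3 `O=Cc1ccc(-c2cn3ccnc3c(-c3ccc4ncn(C5CCCCC5)c4c3)n2)cc1` gives 16.9%. Compound 3 thus stands second highest of the three numbers: its nearest neighbour is compound 1, within the scatter of it, and its furthest is compound 2, beyond the scatter above it. The two measured steps that frame this series are a number 25.4 percentage points higher from compound 1 to compound 2 (beyond the scatter) and a number 17.6 percentage points lower from compound 2 to compound 3 (beyond the scatter).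

Compound 4 `c1ccc2c(-c3cn4ccnc4c(-c4ccc5ncn(C6CCCCC6)c5c4)n3)cccc2c1` differs from compound 3 by naphthalen-1-yl in place of 4-formylphenyl on an aromatic carbon. The step of a number 17.6 percentage points lower from compound 2 to compound 3 (beyond the scatter) bears most directly on this change, since the formyl group that step introduced is now gone; its removal alone would be expected to return the number toward that of compound 2. The step of a number 25.4 percentage points higher from compound 1 to compound 2 (beyond the scatter) shows what a carbon-only aromatic ring in that position gives over bromo. Going by the values given here, no measured step shows what the second fused ring of the naphthalen-1-yl adds, so that part remains open and widens the range. Compound 4 is therefore expected to show an upward step of a number 13.1 percentage points higher from compound 3 to compound 4 (beyond the scatter) in this assay. The estimate for compound 4 is 30%, with a range from 12% to 52%.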

Compound 4, a percentage reported as inhibition, at one concentration (the size of the read-out at that concentration, not a potency): 19.7%
Compound 4: middle estimate off by 10.3 percentage points, on the high side; low and high end bracket the measured number.
By their numbers in this assay, from the lowest: compounds 1, 3 and 4 (each within the scatter of the next, the first and the last beyond it); then compound 2.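

In this assay, the larger naphthalen-1-yl group does not hold the number reached with phenyl at this position on the six-membered aromatic ring with 2 nitrogen, giving a number 14.8 percentage points lower from compound 2 to compound 4 (beyond the scatter), so a second six-membered aromatic ring of carbon only does not add to what the single phenyl ring gives here. The exchange for 4-formylphenyl gives a number 2.8 percentage points higher from compound 3 to compound 4 (within the scatter), which leaves these two groups indistinguishable on this read-out, even though one has a formyl group and the other a second fused ring, while naphthalen-1-yl also gives a number 10.6 percentage points higher from compound 1 to compound 4 (beyond the scatter) against bromo, so compound 2 alone does not define the gain over bromo. No evidence bears on why the number changes with these groups.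

The compounds shown leave open whether any substituent on the phenyl ring of compound 2, such as an amine, a methoxy group or a carboxylic acid, can match or pass its number, since formyl is the only such group here. They also leave open whether naphthalen-2-yl, with its second ring joined differently, would behave like naphthalen-1-yl or like phenyl in this assay.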